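Switching a benzyl amide for a 4-methylphenyl amide

The compounds below may be only part of what the source reports. "The series", "measured", "known", "first", "only" and "open" are said of these compounds alone.

Compound 1 `O=C(NCc1ccccc1)c1csc(-c2c[nH]c3ccccc23)n1` carries a benzyl group on its amide nitrogen. In a functional assay on LNCaP C4-2 cells (Homo sapiens) for cytotoxicity, read by MTT assay, with a stated time of 48 h, in the presence of a further agent that is not named here (on this read-out higher numbers stand for weaker inhibition and lower numbers for stronger inhibition), compound 1 returns > 100000 nM, which is a limit of the assay rather than a measured number. Compound 2 `COc1ccc(NC(=O)c2csc(-c3cn(Cc4ccc(Cl)cc4)c4ccccc34)n2)cc1` also reaches only a limit in this assay, at > 100000 nM. Compound 3 `COc1ccc2[nH]cc(-c3nc(C(=O)Nc4cc(OC)c(OC)c(OC)c4)cs3)c2c1` likewise gives > 100000 nM in this assay, again a limit. Going by the values given here, all three measured compounds therefore sit together at the limit of > 100000 nM in this assay, at which 3 of the 3 values shown sit, and no step between measured compounds can be sized from them.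

Compound 4 `Cc1ccc(NC(=O)c2csc(-c3c[nH]c4ccccc34)n2)cc1` differs from compound 1 in one place: 4-methylphenyl in place of benzyl on an amide-type nitrogen. With every measured compound resting at a limit, the data give no direction for this change. The expected step is a number no higher from compound 1 to compound 4 (the limit leaves the size open), which means no change beyond the scatter is expected. For compound 4 the estimated value in this assay is 100000 nM. The expected range for compound 4 runs from 30000 nM to 300000 nM, and the assay is likely to report only a limit again.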

Compound 4, half-maximal inhibitory concentration: > 100000 nM
Compound 4 ended at the assay's limit; the forecaster's own chance of this, stated with the estimate: 80%; the middle value lies on the limit itself.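

Compound 1 and compound 4 both rest at a limit of the assay, so no step can be read between them, and the same holds across the set: the limit of > 100000 nM in this assay, at which 4 of the 4 values shown sit.

Left open is which change, if any, to these compounds would give a readable number in this assay.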